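The source may report more compounds than this note shows. Statements on the series, on what has been measured and on what is new or still open speak of the compounds shown alone.

Of the compounds shown here, three sharing one core have been measured in a functional assay on MDA-MB-231 cells (Homo sapiens) for inhibition, read by MTT assay, with a stated time of 48 h; a higher number here means a weaker inhibitor of growth, a lower number a stronger inhibitor of growth. Compound 1 (`CCc1cccc(Nc2ncnc3ccc(NC(=S)NCc4ccccc4)cc23)c1`) gives 10500 nM. Compound 2 (`S=C(NCc1ccccc1)Nc1ccc2ncnc(Nc3ccc(Oc4ccccc4)cc3)c2c1`) gives 6800 nM. Compound 3 (`S=C(Nc1ccc(Cl)cc1)Nc1ccc2ncnc(Nc3cccc(Br)c3)c2c1`) gives 8200 nM, which places it within the usual scatter of both other compounds, so these numbers establish no ranking among the three. The next compound to be tested is compound 4 (`S=C(Nc1ccc(Br)cc1)Nc1ccc2ncnc(Nc3cccc(Br)c3)c2c1`), which differs from compound 3 at a single place: bromo in place of chloro on an aromatic carbon. Bromo takes the place of chloro on an aromatic carbon of a six-membered aromatic ring of carbon only, para to a large group. Among the compounds with values here, no pair of measured compounds differs in only one place, so the data give no direct precedent for this change. In this assay, no shift beyond the scatter is expected for this swap, and compound 4 should remain close to compound 3 at 8200 nM. The estimated step is a 1.1-fold lower number from compound 3 to compound 4 (0.04 log units; within the scatter). For compound 4, the expected value is 7500 nM, with an estimated range from 4000 nM to 14000 nM.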

Compound 4, concentration for 50% growth inhibition: > 30000 nM
Compound 4: no number, only a limit (the forecaster's own chance of this, stated with the estimate: 3%); middle value at least 4.0-fold (0.60 log units) away from the limit.
By their numbers in this assay, from the lowest: compounds 2, 3 and 1 (each within the scatter of the next). At a limit, above all of these: compound 4.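

Compound 4 gives no number in this assay, only a limit: the limit of > 30000 nM in this assay, at which 1 of the 4 values shown sits. Bromo in place of chloro, on an aromatic carbon para to a large group, gives an at least 3.6-fold higher number from compound 3 to compound 4 (0.56 log units; beyond the scatter), the only step shown between compounds that differ in one place, and so the first direct evidence about this position. The exchange involves one heavy atom for one heavy atom, with no change in the counted hydrogen-bond donors, acceptors or net charge, yet growth inhibition is not retained within the tested range.

Going by these compounds, how far compound 4 lies past its limit stays open, as does whether fluoro, methyl, methoxy or a carboxylic acid at this place would stay near compound 3. Also open, on these data alone, is whether the same exchange would have this outcome with the benzyl thiourea side chain of compound 1 or compound 2.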